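Benzyl exchange on the shared core

The source may hold more compounds than are shown below. What is called first, only, known or untested is meant among the compounds shown, and "the series" means these compounds.

Compound 1, `Nc1cc(N)c2nc(-c3ccccc3)c(Oc3ccc(Cl)c(Cl)c3)nc2c1`: in a functional assay on RXF 393 cells (Homo sapiens) for inhibition, read by sulforhodamine B assay, with a stated time of 48 h (a lower number here means that less compound is tolerated, a higher number that more compound is tolerated), compound 1 gives < 100000 nM, which is a limit of the assay rather than a number.
Compound 2, `Nc1cc(N)c2nc(-c3ccccc3)c(NCc3ccc(Cl)c(Cl)c3)nc2c1`: in this assay compound 2 gives < 100000 nM, again only a limit.

Compound 2 therefore stands at the limit and nowhere else, as the limit of < 100000 nM in this assay, at which 2 of the 2 values shown sit, shows. Compound 3, `Nc1cc(N)c2nc(-c3ccccc3)c(NCc3ccc(F)cc3)nc2c1`, differs from compound 2 by 4-fluorophenyl in place of 3,4-dichlorophenyl on a saturated chain carbon bound to a nitrogen on an aromatic ring. For the measured compounds named here, no measured pair covers this exchange. With both known values resting at the limit, the expected step that the limit leaves unreadable from compound 2 to compound 3 in this assay is none beyond the scatter. Compound 3 is expected to give about 40000 nM, within 8000 nM to 100000 nM, and most likely to be reported again only as a limit.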

Compound 3, concentration lethal to 50% of the cells: 60300 nM
For compound 3 the middle estimate is 1.5-fold (0.18 log units) below the measured one; measured number inside the range.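

No step from compound 1 or compound 2 to compound 3 can be read in this assay, since compound 1 and compound 2 stand only at a limit: the limit of < 100000 nM in this assay, at which 2 of the 3 values shown sit.

On these data alone, how 4-fluorobenzyl compares with 3,4-dichlorobenzyl on the shared core in this assay remains open.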